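Halogen swap on the pendant phenyl ring

The compounds below may be only part of what the source reports. "The series", "measured", "known", "first", "only" and "open" are said of these compounds alone.

Compound 1 `NS(=O)(=O)c1ccc2nc(N3N=C(c4ccc(Cl)cc4)CC3c3ccccc3)sc2c1`: 68.3%
Compound 2 `COc1ccc(C2CC(c3ccc(Cl)cc3)=NN2c2nc3ccc(S(N)(=O)=O)cc3s2)cc1`: 67.7%
Compound 3 `NS(=O)(=O)c1ccc2nc(N3N=C(c4ccc(Cl)cc4)CC3c3ccc(Cl)cc3)sc2c1`: 14%

In a functional assay on the whole organism (strain Wistar) for inhibition, with Rattus norvegicus as the target, read by paw edema, with stated times of 1 h and 5 h, at a dose of 20 mg/kg by the oral route (a higher number here means more inhibition at the dose given (going by the name of the read-out), a lower number less inhibition), compound 3 gives 14%, the lowest of the three values, far beneath both neighbours. Compound 4 `NS(=O)(=O)c1ccc2nc(N3N=C(c4ccc(Cl)cc4)CC3c3ccc(F)cc3)sc2c1` differs from compound 3 in one place: fluoro in place of chloro on an aromatic carbon. Among the measured compounds shown here, two measured steps bear on this carbon: a number 54.3 percentage points lower from compound 1 to compound 3 (beyond the scatter) and a number 53.7 percentage points lower from compound 2 to compound 3 (beyond the scatter), both large downward moves when chloro arrives there. For the measured compounds named here, no measured compound carries fluoro at this position, so the size of the return is uncertain; the expectation is a substantial rise, a number 28 percentage points higher from compound 3 to compound 4 (beyond the scatter), without fully reaching the hydrogen or methoxy analogues. Compound 4 is therefore estimated at 42%, within a range of 15% to 68%.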

Compound 4, a percentage reported as inhibition, in the whole organism at one dose (the size of the read-out at that dose, not a potency): 14%
Compound 4: the middle estimate sits 28 percentage points above what was measured; the measured number lies below the stated range.
By their numbers in this assay, from the lowest: compounds 3 and 4 (each within the scatter of the next); then compounds 2 and 1 (each within the scatter of the next).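

In this assay, the step from 4-chlorophenyl to 4-fluorophenyl gives no change at the digits printed from compound 3 to compound 4 (within the scatter), so the loss at this carbon is not particular to chloro. Fluoro brings the same large fall, with a number 54.3 percentage points lower from compound 1 to compound 4 (beyond the scatter) and a number 53.7 percentage points lower from compound 2 to compound 4 (beyond the scatter), which places the two halogens together and apart from hydrogen and methoxy among these compounds. Nothing available here accounts for why the two halogens read alike. As far as these compounds go, whether bromo, a hydroxyl or an amine on this carbon would read with the halogens or with hydrogen and methoxy remains open.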